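This account rests on a few compounds, and the source may have more. Where it says the series, first, only, none or still open, it means among the compounds named here.

Compound 3 `Cn1ccc2cc(-c3cnccc3/C=C/C(=O)O)ccc21` gives 102% in an assay on a protein complex for inhibition of CDK8/Cyclin C (Homo sapiens), with a stated time of 1 h, tested at 10 uM; a higher number here means more inhibition at the concentration tested (going by the name of the read-out), a lower number less inhibition. Its number sits within the usual scatter of the two other measured compounds: compound 1 `CCOC(=O)/C=C/c1ccncc1-c1ccc2c(ccn2C)c1`, which gives 100%, and compound 2 `Cn1ccc2cc(-c3cnccc3/C=C/C(=O)N3CCOCC3)ccc21`, which gives 97%. Compound 4 `CNC(=O)/C=C/c1ccncc1-c1ccc2c(ccn2C)c1` differs from compound 3 by methylamino in place of hydroxy on a carbonyl carbon. The measured steps that bear on this change are both at the same carbonyl carbon: from compound 1 to compound 3 the change was a number 2 percentage points higher from compound 1 to compound 3 (within the scatter), and from compound 2 to compound 3 it was a number 5 percentage points higher from compound 2 to compound 3 (within the scatter). Neither exchange at this position moved the inhibition beyond the scatter, so the step to compound 4 is expected to be a number 4 percentage points lower from compound 3 to compound 4 (within the scatter). Compound 4 is therefore estimated at 98%, with a range from 88% to 104%.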

Compound 4, a percentage reported as inhibition, at one concentration (the size of the read-out at that concentration, not a potency): 99%
Compound 4: middle estimate off by 1 percentage points, on the low side, and the stated range covers the measured number.
By their numbers in this assay, from the lowest: compounds 2, 4, 1 and 3 (each within the scatter of the next).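

In the assay this assay, methylamino joins hydroxy, ethoxy and morpholin-4-yl on this carbonyl carbon with a number 3 percentage points lower from compound 3 to compound 4 (within the scatter) and a number 2 percentage points higher from compound 2 to compound 4 (within the scatter) and a number 1 percentage points lower from compound 1 to compound 4 (within the scatter) as its steps. All four groups on this carbon therefore give numbers within the scatter of one another. No measured evidence explains this sameness.

On these data alone, with a single tested concentration and all four numbers close together, any difference in potency stays open. Also open, as far as these compounds go, is whether a larger group on this carbon, such as a longer chain on the amide nitrogen or a benzylamino group, would change the inhibition.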